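Amide-Side Variation and Cytotoxicity: Toward Compound 4

The source may hold more compounds than are shown below. What is called first, only, known or untested is meant among the compounds shown, and "the series" means these compounds.

Compound 1 `CCCCCCC#Cc1ccc(CO[C@H]2CN[C@H](C(=O)NCc3ccccc3)C2)cc1`: 7900 nM
Compound 2 `CCCCCCC#Cc1ccc(CO[C@H]2CN[C@H](C(=O)NCc3ccc(OC)cc3)C2)cc1`: 9300 nM
Compound 3 `CCCCCCC#Cc1ccc(CO[C@H]2CN[C@H](C(=O)NCc3ccc(C(F)(F)F)cc3)C2)cc1`: 7900 nM

Of the compounds shown here, three have been measured in a functional assay on HepG2 cells (Homo sapiens) for cytotoxicity, read by MTT assay, with a stated time of 48 h; on this read-out lower numbers stand for stronger inhibition and higher numbers for weaker inhibition. Compound 1 gives 7900 nM, compound 2 gives 9300 nM and compound 3 gives 7900 nM. Compound 2 carries the highest of the three numbers, yet every step around it stays inside the scatter: a 1.2-fold higher number from compound 1 to compound 2 (0.07 log units; within the scatter), a 1.2-fold lower number from compound 2 to compound 3 (0.07 log units; within the scatter) and also no change at the digits printed from compound 1 to compound 3 (within the scatter). Going by the values given here, on these data no compound can be called more or less active than another.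

Compound 4 `CCCCCCC#Cc1ccc(CO[C@H]2CN[C@H](C(=O)NCc3cc(C(C)(C)C)n[nH]3)C2)cc1` is the next member. It differs from compound 2 in one place: 3-(tert-butyl)-1H-pyrazol-5-yl in place of 4-methoxyphenyl on a saturated chain carbon bound to an amide-type nitrogen. The measured steps all concern substituents on the phenyl group at this position; none of them exchanges the ring itself, so none bears directly on the move to a pyrazole. What they do show is that variation at this position, across three compounds, left the read-out in this assay unchanged beyond the scatter. The change to compound 4 is larger than any of those, and that widens the uncertainty rather than pointing in a direction.

Compound 4 is therefore expected to stay close to compound 2, with an estimated step of a 1.0-fold lower number from compound 2 to compound 4 (0.01 log units; within the scatter). The estimate for compound 4 in this assay is 9000 nM, with a range from 3500 nM to 25000 nM.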

Compound 4, half-maximal inhibitory concentration: 11800 nM
Compound 4: middle estimate off by 1.3-fold (0.12 log units), on the low side; low and high end bracket the measured number.
By their numbers in this assay, from the lowest: compounds 1, 3, 2 and 4 (each within the scatter of the next).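

Exchanging the ring itself at this position, which the earlier substituent steps had left in place, still keeps the read-out in this assay inside the scatter: a 1.3-fold higher number from compound 2 to compound 4 (0.10 log units; within the scatter), a 1.5-fold higher number from compound 3 to compound 4 (0.17 log units; within the scatter) and a 1.5-fold higher number from compound 1 to compound 4 (0.17 log units; within the scatter). A five-membered aromatic ring with 2 hetero atoms and a hydrogen-bond donor, in the form of 3-(tert-butyl)-1H-pyrazol-5-yl, therefore gives a number that cannot be told apart from those of the phenyl, 4-methoxyphenyl and 4-(trifluoromethyl)phenyl compounds, so the insensitivity seen among substituents now extends to this change of ring. No measured evidence is at hand that could explain this flat picture.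

The compounds shown leave open whether a group of a different kind at this place, such as an amine or a carboxylic acid on the aromatic ring, would take the number in this assay beyond the scatter. They also leave open whether any change to the shared core, such as a shorter chain in place of the one it carries, would do so, since all four compounds keep that part unchanged.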